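This account rests on a few compounds, and the source may have more. Where it says the series, first, only, none or still open, it means among the compounds named here.

Measured in a functional assay on CWR22R cells (Homo sapiens) for antiproliferative activity, read by CCK-8 assay, with a stated time of 6 days; on this read-out lower numbers stand for stronger inhibition and higher numbers for weaker inhibition:
- Compound 1 `C[C@@H](Cn1ccc(-c2ccc(C#N)c(Cl)c2)n1)Nc1ccccn1`: > 30000 nM
- Compound 2 `C[C@@H](Cn1ccc(-c2ccc(C#N)c(Cl)c2)n1)Nc1cccc2ccccc12`: > 30000 nM

Compound 1 gives > 30000 nM, which is a limit of the assay and not a number. Compound 2 gives > 30000 nM, which is also a limit. The two compounds therefore share one position, (the limit of > 30000 nM in this assay, at which 2 of the 2 values shown sit), and no order can be drawn between them.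

Compound 3 `C[C@@H](Cn1ccc(-c2ccc(C#N)c(Cl)c2)n1)Nc1ncnc2nc[nH]c12` keeps the core of compound 1 and changes only the group on the amine nitrogen: a group of 9 heavy atoms (5 carbon, 4 nitrogen; one five-membered aromatic ring with 2 hetero atoms, one six-membered aromatic ring with 2 hetero atoms) in place of a group of 6 heavy atoms (5 carbon, 1 nitrogen; one six-membered aromatic ring with 1 hetero atom), on an amine nitrogen. The pyridin-2-yl group leaves, and a larger group with a five-membered and a six-membered aromatic ring enters. Among the compounds with values here, no step between measured compounds gives a size to go by, so the expectation remains loose. In this assay the change is expected to be modest and towards stronger inhibition, and it is estimated as an at least 3.0-fold lower number from compound 1 to compound 3 (0.47 log units; beyond the scatter). Compound 3 may also remain at the same limit. For compound 3 the estimated value is 10000 nM, with an expected range from 2000 nM to 30000 nM.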

Compound 3, half-maximal inhibitory concentration: 4240 nM
Beside the measured number, compound 3's estimate is 2.4-fold (0.37 log units) above it, within the range that was stated.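

Within the data shown here, compound 3 is the first compound in this assay to give a measured number instead of a limit, which shows that the group on the amine nitrogen can by itself bring the series into the measurable range. Exchanging pyridin-2-yl for the larger group with a five-membered and a six-membered aromatic ring gives an at least 7.0-fold lower number from compound 1 to compound 3 (0.84 log units; beyond the scatter), and this size is only a lower bound, as the starting point is a limit and the full step cannot be read. Compound 3 now stands apart from the two earlier compounds, whose different groups at this nitrogen both left them at the limit: the limit of > 30000 nM in this assay, at which 2 of the 3 values shown sit.

The compounds shown leave open which part of the entering group carries the step, whether the ring hydrogen-bond donor, the ring nitrogens or the presence of the second ring. Also open, going by these compounds, is whether a single pyrimidin-4-yl or imidazole ring on the amine nitrogen would go as far, and whether a methyl group on the ring nitrogen that holds the hydrogen would keep the number measurable.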